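The source may hold more compounds than are shown below. What is called first, only, known or untested is meant among the compounds shown, and "the series" means these compounds.

In an ADME assay on J774.1 cells (Mus musculus) for cytotoxicity, read by resazurin assay, with a stated time of 48 h (a lower number here means a stronger inhibitor, a higher number a weaker inhibitor), compound 1 `NC(=O)C1CCN(c2cc3c(cc2F)c(=O)c(C(=O)NCc2ccco2)cn3C2CC2)CC1` reaches only the limit of the measurement, > 100000 nM. Compound 2 `NC(=O)C1CCN(c2cc3c(cc2F)c(=O)c(C(=O)O)cn3C2CC2)CC1` likewise stops at a limit in this assay, giving > 100000 nM. The step that the two limits leave unreadable from compound 1 to compound 2 therefore cannot be sized, and the limit of > 100000 nM in this assay, at which 2 of the 2 values shown sit, is all the numbers show. Compound 3 `CCCCn1cc(C(=O)NCc2ccco2)c(=O)c2cc(F)c(N3CCC(C(N)=O)CC3)cc21` differs from compound 1 in one place: butyl in place of cyclopropyl on an aromatic nitrogen. Within the data shown here, no measured step touches this position, so the expectation rests on compound 1 alone, with its value > 100000 nM. Compound 3 is expected to show 150000 nM, within 40000 nM to 600000 nM, most likely again only a limit. That estimate means a step that the limit leaves unreadable from compound 1 to compound 3.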

Compound 3, half-maximal inhibitory concentration: 41400 nM
The estimate for compound 3 lay 3.6-fold (0.56 log units) above the measured number; low and high end bracket the measured number.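

At the aromatic nitrogen, butyl in place of cyclopropyl gives an at least 2.4-fold lower number from compound 1 to compound 3 (0.38 log units; beyond the scatter) in this assay, so this position can move the number where the earlier change could not be sized. An open butyl chain and a cyclopropyl ring are therefore not interchangeable here. Compound 3 alone gives a number rather than a limit, so this step is only a minimum: the limit of > 100000 nM in this assay, at which 2 of the 3 values shown sit.

On these data alone, whether losing the ring or adding chain length matters remains open, and an ethyl or hexyl chain or a cyclobutyl ring on this nitrogen could help separate the two. Also open, as far as these compounds go, is whether butyl would lower the number with the carboxylic acid of compound 2 in place.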